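Swapping fluoro for amino on a boron-bearing enone

This account rests on a few compounds, and the source may have more. Where it says the series, first, only, none or still open, it means among the compounds named here.

Of the compounds shown here, three built on one shared core have been tested in a functional assay on SK-OV-3 cells (Homo sapiens) for cytotoxicity, read by MTT assay, with a stated time of 48 h; a higher number here means a weaker inhibitor, a lower number a stronger inhibitor. Compound 1 `Cn1cccc1C(=O)/C=C/c1ccc2c(c1)B(O)OC2` gives 93600 nM. Compound 2 `O=C(/C=C/c1ccc2c(c1)B(O)OC2)c1ccc(F)cc1` gives 1400 nM, and compound 3 `O=C(/C=C/c1ccc2c(c1)B(O)OC2)c1ccc(O)cc1` gives 13000 nM. Compound 2 thus stands lowest of the three, separated from its neighbours by a 9.3-fold higher number from compound 2 to compound 3 (0.97 log units; beyond the scatter) and a 67-fold lower number from compound 1 to compound 2 (1.83 log units; beyond the scatter). The unmeasured compound 4 `Nc1ccc(C(=O)/C=C/c2ccc3c(c2)B(O)OC3)cc1` differs from compound 2 in one place: amino in place of fluoro on an aromatic carbon. The step that bears most directly on this change is the one where hydroxy replaced fluoro on an aromatic carbon of the same ring, a 9.3-fold higher number from compound 2 to compound 3 (0.97 log units; beyond the scatter), a modest rise. Because a 9.3-fold higher number from compound 2 to compound 3 (0.97 log units; beyond the scatter) accompanied that exchange, and amino, like hydroxy, is counted as a hydrogen-bond donor and acceptor where fluoro is not, a rise of comparable modest size is expected for compound 4. Compound 4 is therefore estimated at 8000 nM, within 2500 nM to 25000 nM. This corresponds to an expected step of a 5.7-fold higher number from compound 2 to compound 4 (0.76 log units; beyond the scatter).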

Compound 4, half-maximal inhibitory concentration: 20200 nM
The estimate for compound 4 lay 2.5-fold (0.40 log units) below the measured number; low and high end bracket the measured number.
By their numbers in this assay, from the lowest: compound 2; then compounds 3 and 4 (each within the scatter of the next); then compound 1.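

In this assay a second replacement of fluoro on this aromatic carbon also raises the number, with a 14-fold higher number from compound 2 to compound 4 (1.16 log units; beyond the scatter) for amino, and the amino and hydroxy compounds cannot be told apart, with a 1.6-fold higher number from compound 3 to compound 4 (0.19 log units; within the scatter) in that exchange. The 4-aminophenyl group still gives a lower number than 1-methyl-1H-pyrrol-2-yl, with a 4.6-fold lower number from compound 1 to compound 4 (0.67 log units; beyond the scatter) for that replacement, so all three phenyl compounds lie on the same side of compound 1. Nothing measured here accounts for the difference between fluoro and the other two groups.

The compounds shown carry only fluoro, hydroxy and amino at this position, so it remains open whether the low number of compound 2 belongs to fluoro alone or would recur with chloro, methyl or methoxy. On these data alone, whether dimethylamino or a carboxylic acid would track with amino and hydroxy also remains open.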